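The source may report more compounds than this note shows. Statements on the series, on what has been measured and on what is new or still open speak of the compounds shown alone.

Measured so far:
- compound 1 `C[C@H](Cc1ccccc1-c1ccccc1)C1=NCCN1`: 2240 nM
- compound 2 `CC(Cc1ccccc1-c1ccccc1)C1=NCCN1`: 155 nM

In an assay on PC-12 cells for displacement of a labelled ligand from Nischarin (Rattus norvegicus) (a higher number here means a weaker inhibitor, a lower number a stronger inhibitor), compound 1 gives 2240 nM, the highest of the two numbers; compound 2 gives 155 nM. Between them a 14-fold lower number from compound 1 to compound 2 (1.16 log units; beyond the scatter). The single point of difference is the fact that one of compounds 1 and 2 is drawn with a defined configuration and the other without, at the place where they differ, so this one measured step bears directly on the configuration at the chain stereocentre.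

Compound 3 `C[C@@H](Cc1ccccc1-c1ccccc1)C1=NCCN1` differs from compound 1 as follows: the two compounds have the same atoms and bonds and differ only in configuration as drawn: 1 of 1 stereo elements differ; a stereocentre at a saturated chain carbon is drawn R in compound 1 and S in compound 3. Among the measured compounds shown here, the only measured step that bears on this change is the one from compound 1 to compound 2, and it is large. Given that compound 2, drawn without a configuration at that centre, sits far below compound 1 in this assay, the configuration drawn S in compound 3 is expected to carry the lower number, and the step from compound 1 to compound 3 is expected to be at least as large as that measured step, in the same direction. The expected step is a 28-fold lower number from compound 1 to compound 3 (1.45 log units; beyond the scatter). Compound 3 is therefore estimated at 80 nM in this assay, within a range of 30 nM to 250 nM.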

Compound 3, inhibition constant: 97.7 nM
Beside the measured number, compound 3's estimate is 1.2-fold (0.09 log units) below it, within the range that was stated.
By their numbers in this assay, from the lowest: compounds 3 and 2 (each within the scatter of the next); then compound 1.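

In this assay, the chain stereocentre is now compared between two defined configurations, and the S form against the R form gives a 23-fold lower number from compound 1 to compound 3 (1.36 log units; beyond the scatter); this large step rests on configuration alone: the fact that compounds 1 and 3 differ only in the configuration as drawn. The form drawn without a configuration cannot be told apart from the S form, with a 1.6-fold lower number from compound 2 to compound 3 (0.20 log units; within the scatter), a step that stays within the scatter: the fact that one of compounds 2 and 3 is drawn with a defined configuration and the other without, at the place where they differ. Among these three compounds, compound 1 alone stands apart in this assay, so the earlier indirect reading of this centre is replaced by a comparison of defined forms.

As far as these compounds go, all three compounds share the same atoms and bonds, so it remains open whether the S over R difference survives a change of the group at the stereocentre, such as a longer chain like ethyl, or a change on the shared core, such as a hydroxyl or a fluorine. From the compounds shown here alone, it is also open whether the size of the step holds once the shared core carries an amine or a carboxylic acid, and these three compounds cannot say why the configuration matters.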